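Fluoro on the sulfonyl aryl of the dimethyl series

The compounds below may be only part of what the source reports. "The series", "measured", "known", "first", "only" and "open" are said of these compounds alone.

Of the compounds shown here, two have numbers so far. In an assay on HEK293 cells for displacement of a labelled ligand from 5-hydroxytryptamine receptor 6 (Homo sapiens) (on this read-out lower numbers stand for stronger inhibition and higher numbers for weaker inhibition), compound 1 `O=S(=O)(c1cccc(F)c1)N1CCOc2c(N3CCNCC3)cccc21` gives 10 nM and compound 2 `CC1(C)CN(S(=O)(=O)c2ccccc2)c2cc(F)cc(C3CCNCC3)c2O1` gives 3.98 nM; compound 2 stands lowest of the two, a gap beyond the usual scatter. Compound 3 `CC1(C)CN(S(=O)(=O)c2cccc(F)c2)c2cc(F)cc(C3CCNCC3)c2O1` differs from compound 2 by fluoro in place of hydrogen on an aromatic carbon. Among the measured compounds shown here, no pair of measured compounds isolates this change, so the expectation rests on compound 2 alone and the step of a 1.0-fold higher number from compound 2 to compound 3 (0.00 log units; within the scatter) is expected to stay within the scatter of this assay, with no direction assigned. Compound 3 is therefore estimated at 4 nM, with a range from 1.5 nM to 11 nM.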

Compound 3, inhibition constant: 5.01 nM
Compound 3: the middle estimate sits 1.3-fold (0.10 log units) below what was measured; the range from low to high includes it.
By their numbers in this assay, from the lowest: compounds 2, 3 and 1 (each within the scatter of the next, the first and the last beyond it).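

Replacing phenyl with 3-fluorophenyl on the sulfonyl of the dimethyl series gives (a 1.3-fold higher number from compound 2 to compound 3 (0.10 log units; within the scatter)) in this assay. Among the compounds shown here, this is the first pair to isolate the change, and it shows that this aromatic carbon tolerates fluoro with no shift that can be told from the scatter. Nothing available explains this outcome.
Still open, as far as these compounds go, is whether methoxy, a primary amine or a carboxylic acid on this carbon would keep the number in this range. Also open, from the compounds shown here alone, is whether the same change would behave alike on the core of compound 1.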